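The source may hold more compounds than are shown below. What is called first, only, known or untested is meant among the compounds shown, and "the series" means these compounds.

Of the compounds shown here, two built on the same core have been measured here. In an assay on HEK293 cells for inhibition of N-acylethanolamine-hydrolyzing acid amidase (Rattus norvegicus), read by LC-MS, with a stated time of 30 min (on this read-out lower numbers stand for stronger inhibition and higher numbers for weaker inhibition), compound 1 `O=C(CCCCCc1ccc(F)c(Cl)c1)N1CCOC1=O` gives 26 nM. Compound 2 `O=C(CCCCCc1ccc(Br)cc1)N1CCOC1=O` gives 8510 nM in this assay, the higher of the two numbers and thus the weaker inhibitor, with a gap to compound 1 that lies well beyond the usual scatter of this kind of measurement.

The next compound, compound 3 `O=C(O)c1ccc(CCCCCC(=O)N2CCOC2=O)cc1`, keeps the chain and the shared core but carries a different group on the ring: carboxy in place of bromo on an aromatic carbon. Within the data shown here, no measured pair in this set shows the effect of such a change, so the outcome rests on judgement alone. Compound 2 already sits at the weak end, and the expected move, a 2.4-fold higher number from compound 2 to compound 3 (0.37 log units; beyond the scatter), is toward still weaker inhibition, with a real chance that no number is reached at all. Compound 3 is expected to give about 20000 nM, within a range from 4000 nM to 100000 nM.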

Compound 3, half-maximal inhibitory concentration: > 20000 nM
Compound 3: a limit, no number (the forecaster's own chance of this, stated with the estimate: 35%); the middle value lies on the limit itself.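

Among these compounds, at this ring carbon, para to a large group, carboxy in place of bromo gives an at least 2.3-fold higher number from compound 2 to compound 3 (0.37 log units; beyond the scatter) in this assay, so this is the first direct sign that the position responds to a change of group. The step shows that a group bringing a hydrogen-bond donor and a hydrogen-bond acceptor does not restore inhibition here, and that it moves the result further toward the weak end. Compound 3 has only a limit, not a number, so the step gives a minimum size rather than a true one: the limit of > 20000 nM in this assay, at which 1 of the 3 values shown sits.

Going by these compounds, how far compound 3 lies past that limit stays open, and so does the full size of the step. Also open, on these data alone, is whether an amine or a methyl ester at this ring carbon, or a longer chain, would give a stronger number.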